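The source may report more compounds than this note shows. Statements on the series, on what has been measured and on what is new or still open speak of the compounds shown alone.

Measured compounds in an assay on isolated protein for inhibition of ubiquitin carboxyl-terminal hydrolase 7 (Homo sapiens), with stated times of 30 min and 2 h; on this read-out higher numbers stand for weaker inhibition and lower numbers for stronger inhibition:

- compound 1, `Cn1nc2c(=O)n(CC3(O)CCN(Cc4ccc(-c5ccco5)cc4Cl)CC3)cnc2c1-c1ccc(CNC(=O)C(F)(F)F)cc1`: compound 1 gives 2060 nM
- compound 2, `Cn1nc2c(=O)n(CC3(O)CCN(Cc4ccc(-c5ccncc5)cc4Cl)CC3)cnc2c1-c1ccc(CN)cc1`: compound 2 gives 257 nM

Compound 1 stands at the higher of the two numbers; compound 2 sits at a lower number, and the gap between them lies beyond the scatter. Within the data shown here, the two structures differ in more than one place, so no single step between them is on hand.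

Compound 3, `Cn1nc2c(=O)n(CC3(O)CCN(Cc4ccc(-c5ccco5)cc4Cl)CC3)cnc2c1-c1ccc(CNS(C)(=O)=O)cc1`, is not yet measured. It differs from compound 1 in one place: methylsulfonyl in place of (trifluoromethyl)carbonyl on an amine nitrogen. Among the measured compounds shown here, nothing among the measured compounds tests this change on its own; the only lower number, that of compound 2, comes with a second difference as well. The step from compound 1 to compound 3 is therefore expected to be small, a 1.4-fold lower number from compound 1 to compound 3 (0.14 log units; within the scatter), of no direction beyond the scatter. Compound 3 is estimated at 1500 nM, within a range from 500 nM to 4500 nM.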

Compound 3, half-maximal inhibitory concentration: 65.3 nM
The estimate for compound 3 lay 23-fold (1.36 log units) above the measured number; the whole stated range lies above it.
By their numbers in this assay, from the lowest: compound 3; then compound 2; then compound 1.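

In this assay, what the amine nitrogen carries proves to matter strongly: methylsulfonyl in place of (trifluoromethyl)carbonyl gives a 32-fold lower number from compound 1 to compound 3 (1.50 log units; beyond the scatter) with the rest of the structure unchanged. Among these compounds, this is the first change read in one place alone, so it shows a sensitivity at this nitrogen that compound 1 and compound 2, which differ in more than one place, could not show. No measured evidence here bears on the reason for this step.

From the compounds shown here alone, it remains open whether the step reflects the arrival of methylsulfonyl or the departure of (trifluoromethyl)carbonyl; an acetyl group, an ethylsulfonyl group or the free amine at the same nitrogen would separate the two. Going by these compounds, whether the step holds with the different substituent on the other end of compound 2 is also open.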